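This account rests on a few compounds, and the source may have more. Where it says the series, first, only, none or still open, it means among the compounds named here.

Three compounds in the series are known. Compound 1 `COc1ccc(-c2ccn(CCC(C)C)c(=O)c2C#N)cc1` gives 1150 nM in a functional assay on CHO cells for positive allosteric modulation of metabotropic glutamate receptor 2 (Homo sapiens), read by scintillation counting and GTPgammaS binding, with a stated time of 30 min; on this read-out lower numbers stand for an effect already at smaller amounts and higher numbers for an effect only at larger amounts of compound. Within the data shown here, compound 2 `CC(C)CCn1ccc(-c2ccc(Oc3cccnc3)cc2)c(C#N)c1=O` gives 479 nM in this assay, and the change a 2.4-fold lower number from compound 1 to compound 2 (0.38 log units; beyond the scatter) is the only single-point step among the measured compounds. Compound 3 `CCCCn1ccc(-c2ccc(Oc3cccnc3C)cc2)c(C#N)c1=O` gives 347 nM, the lowest of the three numbers; it lies within the scatter of compound 2 and beyond it relative to compound 1.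

Compound 4 `Cc1ncccc1Oc1ccc(-c2ccn(CCC(C)C)c(=O)c2C#N)cc1` differs from compound 3 by methyl in place of hydrogen on a saturated chain carbon bound to two saturated chain carbons, the same difference that, read one bond further out, turns butyl into isopentyl. Among the measured compounds shown here, no measured step concerns a change of this kind: the one known step, a 2.4-fold lower number from compound 1 to compound 2 (0.38 log units; beyond the scatter), alters the group on the oxygen, not the chain on the ring nitrogen. Compounds 2 and 3, which differ in two places including this chain, show numbers within the scatter of each other. Compound 4 is therefore expected to show a 1.0-fold higher number from compound 3 to compound 4 (0.00 log units; within the scatter) in this assay, and its estimated value is 350 nM, with a range from 150 nM to 800 nM.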

Compound 4, half-maximal effective concentration: 275 nM
Estimate against measurement, compound 4: 1.3-fold (0.10 log units) above; the range from low to high includes it.
By their numbers in this assay, from the lowest: compounds 4, 3 and 2 (each within the scatter of the next); then compound 1.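

In this assay, methyl in place of hydrogen on a saturated chain carbon bound to two saturated chain carbons, which turns butyl into isopentyl, gives a 1.3-fold lower number from compound 3 to compound 4 (0.10 log units; within the scatter), so with 2-methylpyridin-3-yl on the oxygen this change on the chain shows no readable effect. Methyl in place of hydrogen on an aromatic carbon gives a 1.7-fold lower number from compound 2 to compound 4 (0.24 log units; within the scatter), so that methyl shows no readable effect either, whereas 2-methylpyridin-3-yl in place of methyl on the oxygen gives a 4.2-fold lower number from compound 1 to compound 4 (0.62 log units; beyond the scatter), a second group on that oxygen whose step from the methyl ether lies beyond the scatter. No measurement at hand accounts for these numbers. On these data alone, whether a longer chain such as hexyl, or a chain ending in an amine or a carboxylic acid, would keep the number in this range stays open. Also open, as far as these compounds go, is how an ethyl or a chlorine in place of the methyl on the pyridine would read.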